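Methylamino analogue of compound 2: expected maximal response

The source may hold more compounds than are shown below. What is called first, only, known or untested is meant among the compounds shown, and "the series" means these compounds.

Measured so far:
compound 1, `COc1ncnc2c1ncn2C1O[C@H](CO)[C@H](O[C@@H]2OC(CO)[C@H](OP(=O)(O)O)C(OP(=O)(O)O)[C@@H]2O)[C@@H]1OP(=O)(O)O`: 34%
compound 2, `Nc1ncnc2c1ncn2C1O[C@H](CO)[C@H](O[C@@H]2OC(CO)[C@H](OP(=O)(O)O)C(OP(=O)(O)O)[C@@H]2O)[C@@H]1OP(=O)(O)O`: 35%

In a functional assay on the whole organism with Rattus norvegicus as the target (a higher number here means a larger maximal response, a lower number a smaller maximal response), compound 1 gives 34% and compound 2 gives 35%. For the measured compounds named here, the single measured step, a number 1 percentage points higher from compound 1 to compound 2 (within the scatter), lies within the scatter, so compound 2 and compound 1 sit within the scatter of each other and neither can be set above the other.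

Compound 3, `CNc1ncnc2c1ncn2C1O[C@H](CO)[C@H](O[C@@H]2OC(CO)[C@H](OP(=O)(O)O)C(OP(=O)(O)O)[C@@H]2O)[C@@H]1OP(=O)(O)O`, differs from compound 2 by methyl in place of hydrogen on a nitrogen on an aromatic ring. Going by the values given here, the only step that bears on this is a number 1 percentage points higher from compound 1 to compound 2 (within the scatter), which altered the same position of the shared core and left this assay unchanged beyond the scatter. Among the compounds with values here, no step adding a methyl to that nitrogen has been measured, so the data give no ground for a direction. A step of no change at the digits printed from compound 2 to compound 3 (within the scatter) is therefore expected, none beyond the scatter.

Compound 3 is estimated at 35% in this assay, with a range from 20% to 50%.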

Compound 3, largest response reached (reported as maximal response), in percent of the reference or control that the assay uses: 37%
Beside the measured number, compound 3's estimate is 2 percentage points below it, and the stated range covers the measured number.
By their numbers in this assay, from the lowest: compounds 1, 2 and 3 (each within the scatter of the next).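

In this assay, methyl in place of hydrogen on the nitrogen on the aromatic ring gives a number 2 percentage points higher from compound 2 to compound 3 (within the scatter), so this first substitution on that nitrogen does not separate compound 3 from compound 2. Methylamino in place of methoxy on the aromatic carbon gives a number 3 percentage points higher from compound 1 to compound 3 (within the scatter), which places all three groups read so far at this position, methoxy, amino and methylamino, within the scatter of one another. Nothing at hand explains why these values stay together.

From the compounds shown here alone, whether a bulkier replacement at this position, such as dimethylamino, a longer chain on the nitrogen or a carboxylic acid on the aromatic carbon, would move the maximal response beyond the scatter remains open. Also open, going by these compounds, is whether a change elsewhere on the shared core, such as removing a phosphate, would shift it.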